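Methyl for Methoxy on Two Related Cores

A few compounds are considered here, and "the series" means these few. Any claim that something is new, unique, unknown or untested is made for them only; others in the source may bear on it.

In an assay on CHO cells for displacement of a labelled ligand from C-X-C chemokine receptor type 3 (Homo sapiens), with a stated time of 60 min (on this read-out lower numbers stand for stronger inhibition and higher numbers for weaker inhibition), three compounds have been measured.
Compound 1, `Cc1cc(CN(CC2CC2)C(CC(=O)O)c2ccc(Cl)cc2)ccc1OCCn1c(=O)ccn(C)c1=O`, gives 91 nM.
Compound 2, `COc1cc(CN(CC2CC2)C(CC(=O)O)c2ccc(Cl)cc2)ccc1OCCn1c(=O)ccn(C)c1=O`, gives 91 nM.
Compound 3, `COc1cc(CN(CC(C)C)C(CC(=O)O)c2ccc(Cl)c(F)c2)ccc1OCCN1C(=O)CCC1=O`, gives 70 nM.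

Compound 1 and compound 2 share one core and differ in a single place: methyl in place of methoxy on an aromatic carbon. That change produced no change at the digits printed from compound 2 to compound 1 (within the scatter). Compound 3 is built on a different core; the difference between the core of compound 3 and the core of compound 2 is not broken down here, so only the two values can be set side by side, and both lie within the usual scatter of each other.

Compound 4, `Cc1cc(CN(CC(C)C)C(CC(=O)O)c2ccc(Cl)c(F)c2)ccc1OCCN1C(=O)CCC1=O`, is the compound not yet measured. It differs from compound 3 by methyl in place of methoxy on an aromatic carbon. Among the measured compounds shown here, this is the same kind of change as the one from compound 2 to compound 1, but the surroundings are not identical: in compound 3 the carbon that changes is ortho to a 2-(2,5-dioxopyrrolidin-1-yl)ethoxy group, whereas in compound 2 it is ortho to a large group.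

The expectation for compound 4 rests on one measured pair. Because the same kind of change gave no change at the digits printed from compound 2 to compound 1 (within the scatter), the step from compound 3 to compound 4 is expected to be no change at the digits printed from compound 3 to compound 4 (within the scatter). Compound 4 is therefore estimated at 70 nM in this assay, with a likely range from 35 nM to 140 nM.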

Compound 4, half-maximal inhibitory concentration in the C-X-C chemokine receptor type 3 assay: 47 nM
The estimate for compound 4 lay 1.5-fold (0.17 log units) above the measured number; measured number inside the range.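

In the C-X-C chemokine receptor type 3 assay, the swap of methoxy for methyl gives a 1.5-fold lower number from compound 3 to compound 4 (0.17 log units; within the scatter), and set beside the earlier pair on the other core, the two steps do not differ: the same change on two cores in the C-X-C chemokine receptor type 3 assay, no change at the digits printed (within the scatter) from compound 2 to compound 1 and a 1.5-fold lower number (0.17 log units; within the scatter) from compound 3 to compound 4, 1.5-fold (0.17 log units) apart, within the scatter of two such steps

This shows that, on the two cores shown here, the swap stayed within the usual scatter each time, so the small step seen on one core was a fair guide to the step on the other; in a physicochemical assay for solubility, at pH 1.1 (on this read-out lower numbers stand for lower solubility and higher numbers for higher solubility), the same swap gives no change at the digits printed from compound 3 to compound 4 (within the scatter), with compound 3 at 3000000 nM and compound 4 at 3000000 nM. It does not show that methyl and methoxy can be exchanged freely across this series, since two pairs are a small sample, and neither step is large enough to reveal whether the core has any influence on the swap.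

What the compounds shown leave open is whether a different group on the same aromatic carbon, such as ethoxy, hydroxyl or an amine, would give a step beyond the scatter in the C-X-C chemokine receptor type 3 assay. Going by these compounds, it also remains open whether a longer chain in place of the 2-(2,5-dioxopyrrolidin-1-yl)ethoxy group would alter the outcome of the methyl-for-methoxy swap.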